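Compound 4: swapping ethynyl for methyl

The source may hold more compounds than are shown below. What is called first, only, known or untested is meant among the compounds shown, and "the series" means these compounds.

- compound 1 `C#CC(C)(C)OC(=O)NN=C1C(Cl)=C(Cl)C(Cl)=C1Cl`: "not determined" (no result reported)
- compound 2 `ClC1=C(Cl)C(Cl)=C(Cl)C1=NNc1cc(Cl)cc(Cl)c1`: 2000 nM
- compound 3 `Fc1ccccc1NN=C1C(Cl)=C(Cl)C(Cl)=C1Cl`: > 3000 nM

All three compounds were tested in a functional assay on MM1.S cells (Homo sapiens) for cytotoxicity, read by MTT assay, with a stated time of 48 h; a higher number here means a weaker inhibitor, a lower number a stronger inhibitor. In this assay, on these data alone, compound 1 stands at "not determined" (no result reported), so it has no place on the scale, and the starting point of this step is unknown. Going by the values given here, compound 2 gives 2000 nM, the only true number so far. For compound 3, > 3000 nM is a limit and not a measured number.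

The next compound to be measured is compound 4 `CC(C)(C)OC(=O)NN=C1C(Cl)=C(Cl)C(Cl)=C1Cl`. The structural change is methyl in place of ethynyl on a saturated chain carbon bound to an oxygen next to a carbonyl group and two saturated chain carbons. In words, methyl takes the place of ethynyl on a saturated chain carbon bound to an oxygen next to a carbonyl group and two saturated chain carbons, so that 1,1-dimethylprop-2-yn-1-yl becomes tert-butyl. The rest of the core of compound 1 stays as it is.

Among the compounds with values here, no measured pair shows what this swap does in this assay. The expectation is therefore a step no larger than the usual scatter, in neither direction. With so little to go on, the estimate leans on compound 2 at 2000 nM. For compound 4 the expected value is 2000 nM, with an estimated range from 500 nM to 5000 nM.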

Compound 4, half-maximal inhibitory concentration: 600 nM
Estimate against measurement, compound 4: 3.3-fold (0.52 log units) above, within the range that was stated.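

In this assay, going by these compounds alone, compound 1 stands at "not determined" (no result reported), so no step to compound 4 can be read, and compound 2 and compound 3 differ from compound 4 in more than one place. The compounds shown leave open what swapping ethynyl for methyl does to the cytotoxicity read-out. Nothing shown bears on the cause of the result for compound 4.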